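This account rests on a few compounds, and the source may have more. Where it says the series, first, only, none or still open, it means among the compounds named here.

Measured so far:
compound 1, `O=C(Cc1ccncc1)c1cc2ccccc2[nH]1`: "not active" (no number reported)
compound 2, `O=C(Cc1cccnc1)c1cc2ccccc2[nH]1`: 13%

Among the measured compounds shown here, in an in vitro assay on P815B cells for inhibition of Indoleamine 2,3-dioxygenase 1 (Mus musculus), tested at 20 uM (a higher number here means more inhibition at the concentration tested (going by the name of the read-out), a lower number less inhibition), compound 2 gives 13%, and this is the only number in hand: compound 1 is reported in this assay as "not active" (no number reported), with no figure attached. Compound 2 therefore stands alone as the single measured point, and no comparison between two numbers can be drawn from it.

Compound 3, `O=C(Cc1cccnc1)c1cc2ccc(F)cc2[nH]1`, has not yet been measured. It differs from compound 2 in one place: fluoro in place of hydrogen on an aromatic carbon. For the measured compounds named here, no pair of measured compounds shows what such a change does here, so there is no step to lean on. The expectation is a step from compound 2 to compound 3 of a number 2 percentage points higher from compound 2 to compound 3 (within the scatter), that is, nothing beyond the usual scatter in either direction. On that basis compound 3 is estimated at 15%, with a range from 0% to 35%.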

Compound 3, a percentage reported as inhibition, at one concentration (the size of the read-out at that concentration, not a potency): "not active" (no number reported)
For compound 3 the study gives words and no number; no gap can be computed for the estimate.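

Among the compounds shown here, no step from compound 2 to compound 3 can be read, since compound 3 is reported in words with no number. No other measurement here bears on this result. In this assay the compounds shown leave open what fluoro in place of hydrogen does to inhibition.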